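The compounds below may be only part of what the source reports. "The series", "measured", "known", "first", "only" and "open" are said of these compounds alone.

Measured compounds:
- compound 1, `C#CCSc1nc(Nc2ccc(Cl)cc2Cl)c2ccncc2n1`: 11000 nM
- compound 2, `CCSc1nc(Nc2cccc(OC)c2)c2ccncc2n1`: 10700 nM

Both numbers come from a functional assay on HepG2 cells (Homo sapiens) for inhibition, read by MTT assay, with a stated time of 72 h; on this read-out lower numbers stand for stronger inhibition and higher numbers for weaker inhibition. In this assay compound 1 gives 11000 nM, and compound 2 gives 10700 nM. These two numbers lie within the usual scatter of each other, so compound 2 cannot be set apart from compound 1 on this evidence; both sit in the same weak range.

Compound 3, `COc1cccc(Nc2nc(SCC3CC3)nc3cnccc23)c1`, differs from compound 2 in one place: cyclopropyl in place of methyl on a saturated chain carbon bound to a sulfur. Among the compounds with values here, no measured pair isolates such a change, and the two measured compounds differ in several places at once, so nothing here shows how the chain at the sulfur matters. The step from compound 2 to compound 3 is therefore expected to be small, at most around the edge of the scatter, and if anything toward a lower number. The estimated step of a 1.3-fold lower number from compound 2 to compound 3 (0.13 log units; within the scatter) reflects that modest expectation. Compound 3 is expected to give about 8000 nM, within a range of 3000 nM to 25000 nM.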

Compound 3, half-maximal inhibitory concentration: 24900 nM
For compound 3 the middle estimate is 3.1-fold (0.49 log units) below the measured one, and the stated range covers the measured number.
By their numbers in this assay, from the lowest: compounds 2 and 1 (each within the scatter of the next); then compound 3.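

In this assay, within the data shown here, putting cyclopropyl in place of methyl on a saturated chain carbon bound to a sulfur gives a 2.3-fold higher number from compound 2 to compound 3 (0.37 log units; beyond the scatter) as the only change between the two compounds. Among these compounds, this single-change pair is the first sign that the group at this position affects the read-out: going from ethyl to cyclopropylmethyl moves the number modestly toward weaker inhibition. Nothing measured here gives a reason for this shift.

The compounds shown leave open how a longer chain such as butyl, or a chain ending in an amine or a carboxylic acid, would behave at this position. As far as these compounds go, it also remains open whether the same change would shift the number in the same direction in a compound carrying the chlorine-bearing ring of compound 1.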